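Dechlorination on the fused core of a chloromethylbenzyl series

The source may hold more compounds than are shown below. What is called first, only, known or untested is meant among the compounds shown, and "the series" means these compounds.

Of the compounds shown here, two have been measured. Compound 1 `ClCc1cccc(Cn2cnc3c(Cl)ncnc32)c1` gives 12300 nM in a functional assay on T47D cells (Homo sapiens) for cytotoxicity, read by sulforhodamine B assay, with a stated time of 48 h; a lower number here means a stronger inhibitor of growth, a higher number a weaker inhibitor of growth. Compound 2 `ClCc1ccc(Cn2cnc3nc(Cl)nc(Cl)c32)cc1` gives 46800 nM in this assay, the higher of the two numbers, and the gap to compound 1 lies beyond the scatter. Compound 3 `ClCc1ccc(Cn2cnc3ncnc(Cl)c32)cc1` is not yet measured. It differs from compound 2 by hydrogen in place of chloro on an aromatic carbon, in words: hydrogen in place of chloro on an aromatic carbon. For the measured compounds named here, no measured pair shows this exact change, so the size of the step is uncertain. Compound 3 shares with compound 1 a single chloro on the fused core and a chloromethyl group on the benzyl ring, so a move toward the number of compound 1 in this assay is expected, meaning a moderate decrease as step a 3.1-fold lower number from compound 2 to compound 3 (0.49 log units; beyond the scatter). For compound 3 the estimate is 15000 nM, with a range from 5000 nM to 45000 nM.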

Compound 3, concentration for total growth inhibition: 2880 nM
Beside the measured number, compound 3's estimate is 5.2-fold (0.72 log units) above it; the measured number lies below the stated range.
By their numbers in this assay, from the lowest: compound 3; then compound 1; then compound 2.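

In this assay, the chloro group on the aromatic carbon between two ring nitrogen atoms is no silent passenger: hydrogen in its place gives a 16-fold lower number from compound 2 to compound 3 (1.21 log units; beyond the scatter), a large step for the loss of one heavy atom. With the chloromethyl group and the other chloro group unchanged in this pair, the step belongs to this single position, and at this position hydrogen gives the stronger growth inhibition. No measurement at hand accounts for the size of the step.

The compounds shown leave open whether any group other than chloro or hydrogen, such as an amine, a methoxy group or a methyl group, is accepted at this position. They also leave open whether the chloro group that remains on the core in compound 3 can be replaced by an amine.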